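This account rests on a few compounds, and the source may have more. Where it says the series, first, only, none or still open, it means among the compounds named here.

Of the compounds shown here, three built on a shared core have been measured in an assay for inhibition of 15-hydroxyprostaglandin dehydrogenase [NAD(+)] (Homo sapiens), read by fluorescence, with a stated time of 15 min, in the presence of a further agent that is not named here; a lower number here means a stronger inhibitor, a higher number a weaker inhibitor. Compound 1 `Nc1c([S+]([O-])CCCCl)sc2nc(-c3cccs3)cc(-c3ccccc3)c12` gives 4 nM, compound 2 `CCC[S+]([O-])c1sc2nc(-c3cccs3)cc(C(=O)O)c2c1N` gives 71 nM, and compound 3 `CCCC[S+]([O-])c1sc2nc(-c3nccs3)cc(-c3ccc(CN)cc3)c2c1N` gives 11.5 nM. Among these three numbers compound 3 stands second highest: compound 1 is its nearest neighbour, with a lower number beyond the scatter, while compound 2 lies furthest away, with a higher number beyond the scatter.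

Compound 4 `CCCC[S+]([O-])c1sc2nc(-c3nccs3)cc(-c3ccc(CCO)cc3)c2c1N` has not yet been measured in this assay. It differs from compound 3 by hydroxymethyl in place of amino on a saturated chain carbon bound to an aromatic carbon, so that aminomethyl gives way to 2-hydroxyethyl on the phenyl of the core. Among the compounds with values here, no pair of measured compounds isolates this change, so nothing measured tells its size directly. Both the leaving and the entering group carry one hydrogen-bond donor and one hydrogen-bond acceptor, and the step from compound 3 to compound 4 in this assay is expected to be small, a 1.4-fold higher number from compound 3 to compound 4 (0.14 log units; within the scatter), a slight rise at most, not clearly beyond the scatter. Compound 4 is therefore estimated at 16 nM, with a range from 5 nM to 50 nM.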

Compound 4, half-maximal inhibitory concentration: 2.9 nM
Compound 4: the middle estimate sits 5.5-fold (0.74 log units) above what was measured; the measured number lies below the stated range.
By their numbers in this assay, from the lowest: compounds 4 and 1 (each within the scatter of the next); then compound 3; then compound 2.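

In this assay, within the data shown here, hydroxymethyl in place of amino on a saturated chain carbon bound to an aromatic carbon gives a 4.0-fold lower number from compound 3 to compound 4 (0.60 log units; beyond the scatter), the first step that isolates a change in one place. It shows that the group carried on the phenyl of the core can move the number beyond the scatter, even though the leaving and entering groups have the same counts of hydrogen-bond donors and acceptors. Nothing available explains this step.

The change replaces nitrogen with oxygen and also lengthens the chain, so the compounds shown do not separate these two parts of the step. A 2-aminoethyl group would address that question, while a longer chain ending in a hydroxyl or a carboxylic acid would show how far this position tolerates further change.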